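Working notes: from compound 2 to compound 4

The compounds below may be only part of what the source reports. "The series", "measured", "known", "first", "only" and "open" are said of these compounds alone.

Measured in a functional assay on OVCAR-3 cells (Homo sapiens) for antiproliferative activity, read by MTT assay, with a stated time of 24 h; a lower number here means a stronger inhibitor, a higher number a weaker inhibitor:
- compound 1 `O=C(NNc1cccc(Cl)c1)c1ccc(NS(=O)(=O)c2cnc(O)nc2O)cc1`: 8410 nM
- compound 2 `O=C(NNc1cccc(Cl)c1)c1cccc(NS(=O)(=O)c2cnc(O)nc2O)c1`: 8040 nM
- compound 3 `O=C(NNC(=O)c1ccccc1Cl)c1ccc(NS(=O)(=O)c2cnc(O)nc2O)cc1`: 5220 nM

Compound 2 stands within the scatter of both compound 1 and compound 3, so these values do not separate. The unmeasured compound 4 `O=C(NNC(=O)c1ccccc1F)c1cccc(NS(=O)(=O)c2cnc(O)nc2O)c1` carries one change on an amine nitrogen: (2-fluorophenyl)carbonyl in place of 3-chlorophenyl on an amine nitrogen. Going by the values given here, the one measured step bearing on it is a 1.6-fold lower number from compound 1 to compound 3 (0.21 log units; within the scatter), where (2-chlorophenyl)carbonyl enters in place of 3-chlorophenyl. Among the compounds with values here, no measured compound carries (2-fluorophenyl)carbonyl, so this is only a close guide. No shift beyond the scatter is therefore expected in this assay. The expected step is a 1.5-fold lower number from compound 2 to compound 4 (0.16 log units; within the scatter). Compound 4 is estimated at 5500 nM, with an expected range of 2500 nM to 12000 nM.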

Compound 4, half-maximal inhibitory concentration: 10800 nM
Estimate against measurement, compound 4: 2.0-fold (0.29 log units) below; low and high end bracket the measured number.
By their numbers in this assay, from the lowest: compounds 3, 2, 1 and 4 (each within the scatter of the next, the first and the last beyond it).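

In this assay, placing (2-fluorophenyl)carbonyl in place of 3-chlorophenyl on an amine nitrogen gives a 1.3-fold higher number from compound 2 to compound 4 (0.13 log units; within the scatter), so this exchange does not separate the two compounds. The same holds for the chlorine-bearing exchange, a 1.6-fold lower number from compound 1 to compound 3 (0.21 log units; within the scatter), so both listed replacements of 3-chlorophenyl by a carbonyl-linked aryl group remain within the scatter. Nothing measured here accounts for these small steps.

On these data alone, the effect of fluorine against chlorine on one unchanged core remains open. So does the reading of a group without an aromatic ring at this nitrogen, such as a longer alkyl chain or a carboxylic acid.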